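The source may hold more compounds than are shown below. What is called first, only, known or untested is meant among the compounds shown, and "the series" means these compounds.

Measured compounds in a functional assay on MKN-45 cells (Homo sapiens) for cytotoxicity, read by MTT assay, with a stated time of 72 h; on this read-out higher numbers stand for weaker inhibition and lower numbers for stronger inhibition:
compound 1, `CN(C)CCn1cnnc1-c1cc(Oc2ccc(NC(=O)N/N=C/c3c[nH]c4ccccc34)cc2F)ccn1`: 790 nM
compound 2, `CN(C)CCn1cnnc1-c1cc(Oc2ccc(NC(=O)N/N=C/c3ccccc3O[N+](=O)[O-])cc2F)ccn1`: 1020 nM
compound 3, `CN(C)CCn1cnnc1-c1cc(Oc2ccc(NC(=O)N/N=C/c3ccc(F)cc3F)cc2F)ccn1`: 810 nM

Compound 3 stands second highest of the three numbers; against compound 1 the step is a 1.0-fold higher number from compound 1 to compound 3 (0.01 log units; within the scatter), and against compound 2 it is a 1.3-fold lower number from compound 2 to compound 3 (0.10 log units; within the scatter). Both lie within the scatter, so no order among the three can be read from them.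

Compound 4, `COc1cc(/C=N/NC(=O)Nc2ccc(Oc3ccnc(-c4nncn4CCN(C)C)c3)c(F)c2)cc(OC)c1OC`, is not yet measured. The change from compound 3 is 3,4,5-trimethoxyphenyl in place of 2,4-difluorophenyl on a carbon with a double bond to nitrogen.

Each measured step bears on this change, since every one exchanges the aryl group on the carbon with a double bond to nitrogen while the shared core stays fixed: a 1.3-fold higher number from compound 1 to compound 2 (0.11 log units; within the scatter), a 1.0-fold higher number from compound 1 to compound 3 (0.01 log units; within the scatter) and a 1.3-fold lower number from compound 2 to compound 3 (0.10 log units; within the scatter). None of them exceeds the scatter. With three different aryl groups giving numbers this close, the expectation for compound 4 in this assay is a step of a 1.0-fold higher number from compound 3 to compound 4 (0.02 log units; within the scatter), that is, no change beyond the scatter. Compound 4 is therefore estimated at 850 nM, with a range from 400 nM to 1800 nM.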

Compound 4, half-maximal inhibitory concentration: 2900 nM
Beside the measured number, compound 4's estimate is 3.4-fold (0.53 log units) below it; measured number outside the range, above it.
By their numbers in this assay, from the lowest: compounds 1, 3 and 2 (each within the scatter of the next); then compound 4.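

In this assay, among these compounds, the aryl group on the carbon with a double bond to nitrogen is not freely exchangeable: 3,4,5-trimethoxyphenyl gives the first steps beyond the scatter at this position (a 3.6-fold higher number from compound 3 to compound 4 (0.55 log units; beyond the scatter)) (a 2.8-fold higher number from compound 2 to compound 4 (0.45 log units; beyond the scatter)) (a 3.7-fold higher number from compound 1 to compound 4 (0.56 log units; beyond the scatter)), and compound 4 is the weakest of the four. The steps from the three earlier aryl groups are close in size, so this group separates from all of them, while 1H-indol-3-yl, 2-(nitrooxy)phenyl and 2,4-difluorophenyl remain within the scatter of one another. No measurement explains the loss.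

The compounds shown leave open whether a single methoxy group on the phenyl ring is enough for this loss or all three are needed. On these data alone, it also remains open whether a phenyl ring carrying an amine or a carboxylic acid would stay with compounds 1, 2 and 3 or fall with compound 4.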